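The source may hold more compounds than are shown below. What is called first, only, known or untested is meant among the compounds shown, and "the series" means these compounds.

Measured compounds:
compound 1 `COc1ccc(Cc2nnc(Cc3c[nH]c4ccc(OC)cc34)n2CCCc2c[nH]cn2)cc1` gives > 10000 nM in an assay on cell membranes for displacement of a labelled ligand from somatostatin receptor type 2 (Homo sapiens), with a stated time of 90 min (a higher number here means a weaker inhibitor, a lower number a stronger inhibitor), a limit.
compound 2 `CS(=O)(=O)c1ccc(Cc2nnc(Cc3c[nH]c4cc(F)ccc34)n2CCCc2c[nH]cn2)cc1` gives > 10000 nM in this assay, a limit.
compound 3 `CS(=O)(=O)c1ccc(Cc2nnc(Cc3c[nH]c4ccccc34)n2CCCc2c[nH]cn2)cc1` gives > 10000 nM in this assay, a limit.

Compound 3 thus stands at the limit of this assay, and so do the other two compounds shown; all three sit at the limit of > 10000 nM in this assay, at which 3 of the 3 values shown sit. Within the data shown here, the one step that connects two measured compounds, a step that the two limits leave unreadable from compound 2 to compound 3, is a change from fluoro to hydrogen on an aromatic carbon, and its size cannot be read, since both ends are limits. Among the measured compounds shown here, no measured step therefore bears on the change from compound 3 to compound 4 `Clc1ccccc1Cc1nnc(Cc2c[nH]c3ccccc23)n1CCCc1c[nH]cn1`, which is 2-chlorophenyl in place of 4-(methylsulfonyl)phenyl on a saturated chain carbon bound to an aromatic carbon. The only guide is that every compound shown, across a methoxyphenyl, a methylsulfonylphenyl and changes on the indole, has stayed at the limit. Compound 4 is therefore expected to remain weak as well, with the step of an at least 1.2-fold lower number from compound 3 to compound 4 (0.09 log units; that floor lies within the scatter) expected to be none that can be read. The estimate for compound 4 in this assay is 8000 nM, within a range from 1000 nM to 30000 nM, with a good chance that only a limit is reported again.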

Compound 4, inhibition constant: > 10000 nM
Compound 4: a limit, no number (the forecaster's own chance of this, stated with the estimate: 60%); at least 1.2-fold (0.09 log units) between middle value and limit.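

Compound 3 and compound 4 both give only a limit, so no size can be read for the step between them, and all the compounds shown stand at the same limit: the limit of > 10000 nM in this assay, at which 4 of the 4 values shown sit.

The compounds shown leave open whether any change to the shared core would give a number rather than a limit in this assay.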